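This account rests on a few compounds, and the source may have more. Where it says the series, first, only, none or still open, it means among the compounds named here.

Of the compounds shown here, two sharing one core have been measured in a functional assay on the whole organism with Mus musculus as the target, with a stated time of 15 min; on this read-out higher numbers stand for an effect only at larger amounts of compound and lower numbers for an effect already at smaller amounts. Compound 1 `Cc1sc2c(F)cccc2c1C1C=CN=CN1` gives 10 mg/kg in this assay, and compound 2 `Cc1sc2ccccc2c1C1C=CN=CN1` gives 3 mg/kg. Among the compounds with values here, the single measured step between them is a 3.3-fold lower number from compound 1 to compound 2 (0.52 log units; beyond the scatter). Compound 2 therefore holds the lower of the two numbers in this assay, with compound 1 standing at a higher number beyond the scatter.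

Compound 3 `Cc1sc2cc(Cl)ccc2c1C1C=CN=CN1` has not yet been measured. It differs from compound 2 in one place: chloro in place of hydrogen on an aromatic carbon. Within the data shown here, the only measured step that bears on this change is a 3.3-fold lower number from compound 1 to compound 2 (0.52 log units; beyond the scatter), in which a halogen leaving the six-membered aromatic ring of the core went with a lower number, although chloro is not fluoro and here it enters at a place meta to a fused ring and para to a fused ring. Since a halogen now enters, a modest upward step in this assay is expected for compound 3, because a 3.3-fold lower number from compound 1 to compound 2 (0.52 log units; beyond the scatter) ran downward when a halogen left. The expected step is a 1.7-fold higher number from compound 2 to compound 3 (0.22 log units; within the scatter). For compound 3 the estimate in this assay is 5 mg/kg, with a range from 2 mg/kg to 15 mg/kg.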

Compound 3, minimum effective dose: 30 mg/kg
Estimate against measurement, compound 3: 6.0-fold (0.78 log units) below; measured number outside the range, above it.
By their numbers in this assay, from the lowest: compound 2; then compound 1; then compound 3.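

In this assay, chloro in place of hydrogen on this aromatic carbon, meta to a fused ring and para to a fused ring, gives a 10-fold higher number from compound 2 to compound 3 (1.00 log units; beyond the scatter), so this position responds strongly to the entry of a single chlorine atom. Read alongside a 3.3-fold lower number from compound 1 to compound 2 (0.52 log units; beyond the scatter), which came with hydrogen replacing fluoro on an aromatic carbon, the new step means that both halogen-bearing compounds shown stand at higher numbers than compound 2, and none of the three goes against this. The data shown offer nothing that accounts for the size of the chloro step.

As far as these compounds go, it remains open whether the higher number belongs to halogens in particular or would come with any group entering at this place, such as a methoxy group or an amine. Also open, from the compounds shown here alone, is whether fluoro at this same place would move the number in the same direction, and whether chloro would do so on the other aromatic carbons of the six-membered ring.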